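Furan-3-yl for Thiophen-3-yl on a Shared Core

The source may hold more compounds than are shown below. What is called first, only, known or untested is meant among the compounds shown, and "the series" means these compounds.

Compound 1 `COc1ccc(C2=C(c3ccoc3)C(=O)N3CCCC3C2)cc1` in a functional assay on HCT-116 cells (Homo sapiens) for cytotoxicity; on this read-out lower numbers stand for stronger inhibition and higher numbers for weaker inhibition: 3000 nM
Compound 2 `CSc1ccc(C2=C(c3ccccc3)C(=O)N3CCCC3C2)cc1` in this assay: 1000 nM
Compound 3 `CSc1ccc(C2=C(c3ccsc3)C(=O)N3CCCC3C2)cc1` in this assay: 600 nM

Compound 3 stands at the lowest of the three numbers. Its nearest neighbour is compound 2, and the measured step of a 1.7-fold lower number from compound 2 to compound 3 (0.22 log units; within the scatter) lies within the usual scatter, so the two cannot be ranked against each other. Compound 1 sits furthest away, beyond the scatter.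

Compound 4 `CSc1ccc(C2=C(c3ccoc3)C(=O)N3CCCC3C2)cc1` differs from compound 3 in one place: furan-3-yl in place of thiophen-3-yl on a double-bonded ring carbon. Among the measured compounds shown here, no measured step covers this exchange. For the measured compounds named here, the one measured step on the same carbon, a 1.7-fold lower number from compound 2 to compound 3 (0.22 log units; within the scatter), concerned a different exchange and was small. Compound 1 carries furan-3-yl but differs from compound 4 in another group as well, so its value and that of compound 3 can only be set side by side, not read as a step.

With little to go on, the estimated step from compound 3 to compound 4 is a 1.5-fold higher number from compound 3 to compound 4 (0.18 log units; within the scatter), a modest rise at most. Compound 4 is therefore expected to give 900 nM in this assay, between 400 nM and 2500 nM.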

Compound 4, half-maximal inhibitory concentration: 1100 nM
The estimate for compound 4 lay 1.2-fold (0.09 log units) below the measured number; the measured number falls inside the stated range.
By their numbers in this assay, from the lowest: compounds 3, 2 and 4 (each within the scatter of the next); then compound 1.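

On the double-bonded ring carbon, furan-3-yl now joins thiophen-3-yl and phenyl as a third ring that cannot be told apart from the others in this assay: the data show a 1.8-fold higher number from compound 3 to compound 4 (0.26 log units; within the scatter) and a 1.1-fold higher number from compound 2 to compound 4 (0.04 log units; within the scatter). Among the compounds shown here, compound 4 also turns the earlier side-by-side look at compound 1 into a true single change, methylsulfanyl in place of methoxy on an aromatic carbon, and a 2.7-fold lower number from compound 1 to compound 4 (0.44 log units; beyond the scatter) is the only step here that lies beyond the scatter. No supporting measurement is available to explain either finding.

From the compounds shown here alone, whether that exchange gives a similar step with phenyl or thiophen-3-yl on the ring carbon remains open. So does the outcome of placing a non-aromatic group there, such as an amine or a longer chain.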